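Ester in place of amine on the shared core

The source may hold more compounds than are shown below. What is called first, only, known or untested is meant among the compounds shown, and "the series" means these compounds.

Compounds measured so far:
Compound 1, `CCOC(=O)C(=O)Nc1ccc(N(C)C)cc1C#N`, 1 mg/kg
Compound 2, `CCOC(=O)C(=O)Nc1ccc(N)cc1C#N`, 1 mg/kg
Compound 3, `CCOC(=O)C(=O)Nc1cccc(N(C)C(C)C)c1C#N`, 0.3 mg/kg

In a functional assay on the whole organism with Rattus norvegicus as the target (on this read-out higher numbers stand for an effect only at larger amounts of compound and lower numbers for an effect already at smaller amounts), compound 3 holds the lowest number of the three; its gap to compound 1 and to compound 2 lies beyond the scatter. The unmeasured compound 4, `CCOC(=O)C(=O)Nc1cccc(C(=O)OC)c1C#N`, differs from compound 3 by methoxycarbonyl in place of isopropyl(methyl)amino on an aromatic carbon. For the measured compounds named here, the only measured step, no change at the digits printed from compound 1 to compound 2 (within the scatter), concerns a different exchange, amino in place of dimethylamino, and does not bear on an ester entering for an amine. Going by the values given here, nothing among the measured compounds tells how this change acts. Compound 4 is therefore expected near the other two compounds, a step of a 3.3-fold higher number from compound 3 to compound 4 (0.52 log units; beyond the scatter), with wide uncertainty. The estimate for compound 4 is 1 mg/kg, between 0.3 mg/kg and 3 mg/kg.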

Compound 4, dose for half-maximal effect: 1.2 mg/kg
Estimate against measurement, compound 4: 1.2-fold (0.08 log units) below; low and high end bracket the measured number.
By their numbers in this assay, from the lowest: compound 3; then compounds 1, 2 and 4 (each within the scatter of the next).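

In this assay, methoxycarbonyl in place of isopropyl(methyl)amino on the aromatic carbon ortho to the cyano group gives a 4.0-fold higher number from compound 3 to compound 4 (0.60 log units; beyond the scatter). For the compounds shown here, this is the first measured exchange at this carbon, and it shows that the read-out responds to the group placed there, with the amine on the side of the lower number. No measurement at hand accounts for this step. The compounds shown leave open how a carboxylic acid or an ethoxycarbonyl group would read at this carbon, and whether a primary amine here would keep the lower number.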